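This account rests on a few compounds, and the source may have more. Where it says the series, first, only, none or still open, it means among the compounds named here.

Working notes on the series.

Of the compounds shown here, three have been measured in a functional assay on A-431 cells (Homo sapiens) for antiproliferative activity, read by MTT assay, with a stated time of 72 h; on this read-out higher numbers stand for weaker inhibition and lower numbers for stronger inhibition. Compound 1 `COc1cc2ncnc(Nc3cccc(Cl)c3)c2cc1OCCCCC(=O)Nc1ccc(S(N)(=O)=O)cc1` gives 30400 nM. Compound 2 `COc1cc2ncnc(Nc3ccccc3)c2cc1OCCCCC(=O)Nc1ccc(S(N)(=O)=O)cc1` gives 25200 nM. Compound 3 `NS(=O)(=O)c1ccc(NC(=S)Nc2ccc3ncnc(Nc4cccc(C(F)(F)F)c4)c3c2)cc1` gives 21700 nM. The three numbers sit close together, and none of the gaps between them is beyond the usual scatter, so no order of potency can be read from them.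

Compounds 1 and 2 share a core and differ in one place, (chloro in place of hydrogen on an aromatic carbon); this change gives a 1.2-fold higher number from compound 2 to compound 1 (0.08 log units; within the scatter). Compound 3 has a different core from compound 2, and the difference between the two cores is not broken down here.

Compound 4 `NS(=O)(=O)c1ccc(NC(=S)Nc2ccc3ncnc(Nc4ccc(Cl)c(C(F)(F)F)c4)c3c2)cc1` has not yet been measured. It differs from compound 3 in one place, (chloro in place of hydrogen on an aromatic carbon). For the measured compounds named here, this is the same kind of change as the one from compound 2 to compound 1, though the surroundings differ: in compound 4 the entering chloro sits ortho to a trifluoromethyl group and para to a large group, whereas in compound 1 it sits meta to a large group, with no trifluoromethyl group on that ring.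

In this assay, going by the values given here, the step from compound 3 to compound 4 is expected to be small, about a 1.2-fold higher number from compound 3 to compound 4 (0.06 log units; within the scatter), set beside the measured step from compound 2 to compound 1; this rests on the one earlier instance of the same kind of change, which stayed within the scatter, and on the fact that all three measured numbers sit in one narrow band. Compound 4 is therefore estimated at 25000 nM, with a likely range from 11000 nM to 55000 nM.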

Compound 4, half-maximal inhibitory concentration: 18200 nM
Estimate against measurement, compound 4: 1.4-fold (0.14 log units) above; low and high end bracket the measured number.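

The change from hydrogen to chloro on an aromatic carbon has now been read on two cores, and in this assay it gives a 1.2-fold lower number from compound 3 to compound 4 (0.08 log units; within the scatter). Set beside the earlier step, the two results do not differ, so the opposite directions of the two steps carry no weight: the same change on two cores in this assay, a 1.2-fold higher number (0.08 log units; within the scatter) from compound 2 to compound 1 and a 1.2-fold lower number (0.08 log units; within the scatter) from compound 3 to compound 4, 1.4-fold (0.16 log units) apart, within the scatter of two such steps This shows that, in both pairs, the change leaves the number within the scatter, whether the chloro enters ortho to a trifluoromethyl group and para to a large group, as in compound 4, or on a ring without a trifluoromethyl group, as in compound 1; it does not show that chloro has any effect of its own on either core, and two pairs cannot establish that the same would hold on any further core, or on a compound whose number lies outside the narrow band shared by compound 1, compound 2, compound 3 and compound 4.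

The compounds shown leave open whether a different group at the same place on the ring of compound 4, such as a nitrile or an amine, would give a step beyond the scatter. They also leave open whether a carboxylic acid in place of the sulfonamide, or a longer chain in the linker of compound 1, would take the number out of this band.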